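Amide aryl swaps on a shared quinoline-piperazine core

This account rests on a few compounds, and the source may have more. Where it says the series, first, only, none or still open, it means among the compounds named here.

Measured so far:
compound 1 `CCN1CCN(c2cc(C)c3cc(NC(=O)c4cccc(Cl)c4)ccc3n2)CC1`, 3820 nM in a functional assay on MCF7 cells (Homo sapiens) for antiproliferative activity, read by MTT assay, with a stated time of 72 h; a higher number here means a weaker inhibitor, a lower number a stronger inhibitor
compound 2 `CCN1CCN(c2cc(C)c3cc(NC(=O)c4ccc(OC)cc4)ccc3n2)CC1`, 7690 nM
compound 3 `CCN1CCN(c2cc(C)c3cc(NC(=O)c4ccc5ccccc5n4)ccc3n2)CC1`, 7060 nM

Compound 3 sits second highest of the three numbers; its nearest neighbour is compound 2 and its furthest compound 1, both within the scatter. Compound 4 `CCN1CCN(c2cc(C)c3cc(NC(=O)c4ccco4)ccc3n2)CC1` differs from compound 3 by furan-2-yl in place of quinolin-2-yl on a carbonyl carbon. Every step measured so far is a swap of the group on the same carbonyl carbon: a 2.0-fold higher number from compound 1 to compound 2 (0.30 log units; within the scatter), a 1.8-fold higher number from compound 1 to compound 3 (0.27 log units; within the scatter) and a 1.1-fold lower number from compound 2 to compound 3 (0.04 log units; within the scatter), none beyond the scatter. By that precedent no step beyond the scatter is expected for compound 4, so a 1.1-fold lower number from compound 3 to compound 4 (0.04 log units; within the scatter) is the estimated change. Compound 4 is expected to give 6500 nM, within 2500 nM to 16000 nM.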

Compound 4, half-maximal inhibitory concentration: 41200 nM
Compound 4: middle estimate off by 6.3-fold (0.80 log units), on the low side, outside the stated range (above it).
By their numbers in this assay, from the lowest: compounds 1, 3 and 2 (each within the scatter of the next); then compound 4.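

In this assay the group on this carbonyl carbon can move the number beyond the scatter, which no earlier swap did: furan-2-yl gives a 5.8-fold higher number from compound 3 to compound 4 (0.77 log units; beyond the scatter), a 5.4-fold higher number from compound 2 to compound 4 (0.73 log units; beyond the scatter) and an 11-fold higher number from compound 1 to compound 4 (1.03 log units; beyond the scatter). Of the four groups, only furan-2-yl is a five-membered ring, and compounds 1, 2 and 3 remain within the scatter of the next in order. Nothing available accounts for this shift.

Still open, on these data alone, is whether thiophen-2-yl or pyridin-2-yl on this carbonyl carbon would fall with compound 4 or with compounds 1, 2 and 3.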